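Benzyl carbamate replacing tert-butyl carbamate: stability outlook

The compounds below may be only part of what the source reports. "The series", "measured", "known", "first", "only" and "open" are said of these compounds alone.

Measured compounds:
Compound 1, `CC(C)COC(=O)N1CCN(C(=O)c2nc(Nc3cc(C4CC4)[nH]n3)c3cc(Cl)ccc3n2)C[C@H]1C`, gives 99% in a physicochemical assay, read by HPLC, in phosphate buffer, with a stated time of 2 h, at pH 7.4; on this read-out higher numbers stand for a more stable compound and lower numbers for a less stable compound.
Compound 2, `C[C@@H]1CN(C(=O)c2nc(Nc3cc(C4CC4)[nH]n3)c3cc(Cl)ccc3n2)CCN1C(=O)OC(C)(C)C`, gives 99.1% in this assay.
Compound 3, `CC(OC(=O)N1CCN(C(=O)c2nc(Nc3cc(C4CC4)[nH]n3)c3cc(Cl)ccc3n2)C[C@H]1C)OC(=O)C(C)(C)C`, gives 90.5% in this assay.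

On the numbers shown, compound 2 sits at one end of the set: it is separated from compound 1 by a number 0.1 percentage points higher from compound 1 to compound 2 (within the scatter) and from compound 3 by a number 8.6 percentage points lower from compound 2 to compound 3 (within the scatter), and both of these steps lie within the scatter. The third measured step, a number 8.5 percentage points lower from compound 1 to compound 3 (within the scatter), is likewise within the scatter. Across all three measured compounds, the changes on the oxygen of the carbamate therefore leave this assay essentially unmoved.

Compound 4, `C[C@@H]1CN(C(=O)c2nc(Nc3cc(C4CC4)[nH]n3)c3cc(Cl)ccc3n2)CCN1C(=O)OCc1ccccc1`, differs from compound 2 by benzyl in place of tert-butyl on an oxygen next to a carbonyl group. For the measured compounds named here, the steps that bear on this change are those that also alter the group on this oxygen, namely a number 0.1 percentage points higher from compound 1 to compound 2 (within the scatter) and a number 8.6 percentage points lower from compound 2 to compound 3 (within the scatter), and neither of them went beyond the scatter. Compound 4 is therefore expected to show no step beyond the scatter, with an estimated change of a number 0.6 percentage points lower from compound 2 to compound 4 (within the scatter) in this assay. Compound 4 is estimated to give 98.5%, within a range of 94% to 100%.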

Compound 4, percent of the compound remaining: 97.7%
Compound 4: the middle estimate sits 0.8 percentage points above what was measured; low and high end bracket the measured number.
By their numbers in this assay, from the lowest: compounds 3, 4, 1 and 2 (each within the scatter of the next).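

Benzyl is the only group on the oxygen next to a carbonyl group among these compounds that brings one six-membered aromatic ring of carbon only, and this assay gives a number 1.4 percentage points lower from compound 2 to compound 4 (within the scatter) for this exchange, so a ring at this position moves the number no further than the scatter. For the compounds shown here, the same holds in the comparison with the isobutyl carbamate, a number 1.3 percentage points lower from compound 1 to compound 4 (within the scatter), and in the comparison with the 1-(((tert-butyl)carbonyl)oxy)ethyl carbamate, a number 7.2 percentage points higher from compound 3 to compound 4 (within the scatter), so no compound in the set of four stands apart from the others and none goes against this reading. Why the number stays put cannot be said, as no measurement offered here speaks to a cause.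

The compounds shown leave open whether a chain ending in an amine or a carboxylic acid on this oxygen, or a longer chain, would also stay within the scatter in this assay and whether a benzyl ring bearing a nitrile would do the same. They also leave open whether the tert-butyl and benzyl carbamates would remain this close in a buffer of another acidity or over a longer time.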